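Esterifying an Acid Chain End Against Paw Edema

The source may hold more compounds than are shown below. What is called first, only, known or untested is meant among the compounds shown, and "the series" means these compounds.

Compound 1 `CCCCCCCCC1=NC(=O)N=C1CCCCCCCC(=O)O` is a long-chain acid built on a shared core. For the measured compounds named here, in a functional assay on the whole organism for inhibition, with Rattus norvegicus as the target, read by paw edema, with a stated time of 3 h, at a dose of 100 mg/kg by the oral route (a lower number here means less inhibition, a higher number more inhibition at the dose given (going by the name of the read-out)), compound 1 gives -12.9%, the lowest of the two numbers known so far. Compound 2 `CCCCCCCCC1=NC(=S)N=C1CCCCCCCC(=O)OCCO` differs from compound 1 in both its core and its chain end; in this assay compound 2 gives -7.17%. The two values lie within the scatter of each other, so no order between them can be read.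

Compound 3 `CCCCCCCCC1=NC(=O)N=C1CCCCCCCC(=O)OCCO[N+](=O)[O-]` has not yet been measured. It differs from compound 1 by 2-(nitrooxy)ethyl in place of hydrogen on an oxygen next to a carbonyl group. Both measured values sit close to zero, and nothing known here shows a change at the chain end moving the number beyond the scatter, so the step is expected to be small, a number 7.9 percentage points higher from compound 1 to compound 3 (within the scatter), in no firm direction. Compound 3 is therefore estimated to give -5% in this assay, within -25% to 15%.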

Compound 3, a percentage reported as inhibition, in the whole organism at one dose (the size of the read-out at that dose, not a potency): -22.8%
For compound 3 the middle estimate is 17.8 percentage points above the measured one, within the range that was stated.
By their numbers in this assay, from the lowest: compounds 3, 1 and 2 (each within the scatter of the next, the first and the last beyond it).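

For the compounds shown here, this is the first comparison at the chain end in which only one place differs. In this assay, 2-(nitrooxy)ethyl in place of hydrogen on an oxygen next to a carbonyl group gives a number 9.9 percentage points lower from compound 1 to compound 3 (within the scatter), so the acid and this ester cannot be told apart at this dose. The step therefore shows no effect of this change that rises above the ordinary spread of the measurement, and nothing known here offers an explanation for the result.

The compounds shown leave open whether a different group at the same place, such as methyl or a longer chain ending in an amine, would move the number beyond the scatter. They also leave open what the hydroxyethyl ester alone does on the core of compound 1, since compound 2 differs from compound 1 in both its core and its chain end.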